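The source may hold more compounds than are shown below. What is called first, only, known or untested is meant among the compounds shown, and "the series" means these compounds.

Working notes on the series. Among the compounds with values here, in a functional assay on the whole organism for inhibition, with Rattus norvegicus as the target, read by paw edema, with stated times of 1 h and 3 h, at a dose of 50 mg/kg by the oral route (a lower number here means less inhibition, a higher number more inhibition at the dose given (going by the name of the read-out)), compound 1 `C/C(=N\OCC(=O)O)c1ccc(C)cc1` gives 20%, the only plain number among the three measured compounds. The other two compounds sit at a limit of the assay (the limit of < 20% in this assay, at which 2 of the 3 values shown sit). Compound 2 `C/C(=N\OCC(=O)O)c1ccc(O)cc1` gives < 20% in this assay, a limit rather than a number. Compound 3 `COc1ccc(/C(C)=N/OCC(=O)O)cc1` gives < 20% in this assay, also a limit. The steps from compound 1 are a number no higher from compound 1 to compound 2 (the limit leaves the size open) and a number no higher from compound 1 to compound 3 (the limit leaves the size open). Compound 4 `C/C(=N\OCC(=O)O)c1ccc([N+](=O)[O-])cc1` differs from compound 1 by nitro in place of methyl on an aromatic carbon. Both measured changes at the same aromatic carbon gave no rise, so no rise is expected for compound 4 either, and the step of a number 5 percentage points lower from compound 1 to compound 4 (within the scatter) is the estimate. Compound 4 is expected to give 15% in this assay, within 5% to 25%.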

Compound 4, a percentage reported as inhibition, in the whole organism at one dose (the size of the read-out at that dose, not a potency): < 20%
Compound 4: only a limit was reported (the forecaster's own chance of this, stated with the estimate: 60%); the middle value does not contradict the limit.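

At this aromatic carbon, nitro in place of methyl in this assay gives a number no higher from compound 1 to compound 4 (the limit leaves the size open), so a third replacement of the methyl, after hydroxy and methoxy, also yields no plain number above that of compound 1. The steps among compound 2, compound 3 and compound 4 cannot be read, so these replacements cannot be ranked. Plain numbers remain scarce at this position: the limit of < 20% in this assay, at which 3 of the 4 values shown sit.

Open, going by these compounds, is the size of each step from compound 1. Also open, on these data alone, is whether an amine, a carboxylic acid or a longer alkyl chain at this carbon would give a readable rise.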